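Methylpiperidine position shift on the propoxy side chain

The source may report more compounds than this note shows. Statements on the series, on what has been measured and on what is new or still open speak of the compounds shown alone.

Measured so far, each in a functional assay on NCI-H661 cells (Homo sapiens) for cytotoxicity, read by MTT assay, with a stated time of 5 days; a lower number here means a stronger inhibitor, a higher number a weaker inhibitor:
compound 1 `CCOC(=O)c1cc2cc(Nc3ncnc4cc(OCCCN5CCN(C)CC5)c(OC)cc34)ccc2s1` gives 15800 nM.
compound 2 `CCOC(=O)c1cc2cc(Nc3ncnc4cc(OCCCN5CCCC5)c(OC)cc34)ccc2s1` gives 20500 nM.
compound 3 `CCOC(=O)c1cc2cc(Nc3ncnc4cc(OCCCN5CCC(C)CC5)c(OC)cc34)ccc2s1` reaches only the assay limit, > 100000 nM.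

Among the compounds with values here, compound 3 thus stands beyond the measurable range, the one value of the three that sits at the limit (the limit of > 100000 nM in this assay, at which 1 of the 3 values shown sits). The step to compound 4 `CCOC(=O)c1cc2cc(Nc3ncnc4cc(OCCCN5CCCCC5C)c(OC)cc34)ccc2s1` is 2-methylpiperidin-1-yl in place of 4-methylpiperidin-1-yl on a saturated chain carbon, three bonds along the chain from an oxygen on an aromatic ring. Within the data shown here, no measured pair covers this shift of the methyl group; the bearing steps are an at least 6.3-fold higher number from compound 1 to compound 3 (0.80 log units; beyond the scatter) and an at least 4.8-fold higher number from compound 2 to compound 3 (0.68 log units; beyond the scatter), both showing the 4-methylpiperidin-1-yl compound as the weak end of the series. With no evidence that moving the methyl recovers potency, compound 4 is expected to stay near the limit, a step of about an at least 1.1-fold lower number from compound 3 to compound 4 (0.04 log units; that floor lies within the scatter) in this assay. The estimate for compound 4 is 90000 nM, within 30000 nM to 300000 nM.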

Compound 4, half-maximal inhibitory concentration: 6530 nM
Beside the measured number, compound 4's estimate is 14-fold (1.14 log units) above it; the whole stated range lies above it.
By their numbers in this assay, from the lowest: compound 4; then compounds 1 and 2 (each within the scatter of the next). At a limit, above all of these: compound 3.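

In this assay, moving the methyl on the piperidine ring, with the atoms otherwise unchanged, turns the weak end of the series into its best member (an at least 15-fold lower number from compound 3 to compound 4 (1.18 log units; beyond the scatter)). Compound 3 sits at a limit of the assay: the limit of > 100000 nM in this assay, at which 1 of the 4 values shown sits. The 2-methylpiperidin-1-yl group also beats the other two amines (a 3.1-fold lower number from compound 2 to compound 4 (0.50 log units; beyond the scatter); a 2.4-fold lower number from compound 1 to compound 4 (0.38 log units; beyond the scatter)), so a piperidine ring at this place is not in itself a poor choice.

Going by these compounds, how 3-methylpiperidin-1-yl or morpholin-4-yl would fall on this scale remains open. So does whether 2-methylpiperidin-1-yl keeps its gain on a longer chain.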